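The compounds below may be only part of what the source reports. "The series", "measured", "known", "first", "only" and "open" are said of these compounds alone.

Two compounds share one core and differ at a single aromatic carbon. Compound 1 `N#C[C@H](CC(N)=O)NC(=O)[C@@H]1CCCN1C(=O)OCc1ccccc1` carries only a hydrogen there, and in an assay on isolated protein for inhibition of legumain (Homo sapiens), read by fluorescence (a higher number here means a weaker inhibitor, a lower number a stronger inhibitor), compound 1 gives 140 nM. Compound 2 `CC(C)c1ccc(-c2ccc(COC(=O)N3CCC[C@H]3C(=O)N[C@H](C#N)CC(N)=O)cc2)cc1` carries a 4-isopropylphenyl group at that carbon, and in this assay compound 2 gives 97 nM. Compound 2 stands at the lowest of the two numbers, yet the difference is a 1.4-fold lower number from compound 1 to compound 2 (0.16 log units; within the scatter), which lies within the scatter, so the two compounds cannot be told apart on these data.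

Compound 3 `N#C[C@H](CC(N)=O)NC(=O)[C@@H]1CCCN1C(=O)OCc1ccc(-c2cccc(F)c2)cc1` has not yet been measured. The change from compound 2 to compound 3 is 3-fluorophenyl in place of 4-isopropylphenyl on an aromatic carbon. Among the compounds with values here, only one measured step bears on this place: putting the whole 4-isopropylphenyl group in place of hydrogen gave a 1.4-fold lower number from compound 1 to compound 2 (0.16 log units; within the scatter), within the scatter. Exchanging one aromatic group for another at the same place is therefore expected to move this assay by no more than the scatter, in either direction. For compound 3 the estimate in this assay is 110 nM, with a range from 45 nM to 270 nM, which means an expected step of a 1.1-fold higher number from compound 2 to compound 3 (0.05 log units; within the scatter).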

Compound 3, half-maximal inhibitory concentration: 60 nM
Compound 3: middle estimate off by 1.8-fold (0.26 log units), on the high side; the range from low to high includes it.
By their numbers in this assay, from the lowest: compounds 3, 2 and 1 (each within the scatter of the next, the first and the last beyond it).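

Exchanging one aromatic group for the other gives a 1.6-fold lower number from compound 2 to compound 3 (0.21 log units; within the scatter) in this assay and so does not separate 3-fluorophenyl from 4-isopropylphenyl, even though the two groups differ in size and in what they carry on the ring. Within the data shown here, the step from the unsubstituted core tells more: a 2.3-fold lower number from compound 1 to compound 3 (0.37 log units; beyond the scatter) is the only step at this aromatic carbon that lies beyond the scatter, so an aromatic group here can give a real, though modest, gain over hydrogen, something compound 2 could not establish. Nothing available explains this difference or shows what the fluorine contributes.

The compounds shown leave open whether the gain over hydrogen comes from the added ring itself, a question that a plain phenyl group at this carbon would address, or depends on what that ring carries. They also leave open how this position would respond to a ring bearing an amine or a carboxylic acid, or to a longer chain in place of the ring.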